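The source may report more compounds than this note shows. Statements on the series, on what has been measured and on what is new or still open speak of the compounds shown alone.

Compound 1 `CCC(C)(C)Cc1c[nH]c(CCc2ccc(-c3cccc(N)n3)cc2)n1` and compound 2 `c1ccc(-c2ccc(CCc3nc(CC4CCCC4)c[nH]3)cc2)nc1` share a core and have both been tested in a functional assay on HEK293 cells for agonist activity at Bombesin receptor subtype-3 (Homo sapiens), read by luminescence and calcium flux, with a stated time of 10 min; a lower number here means that less compound is needed, a higher number that more compound is needed for the effect. Compound 1 gives 37 nM, and compound 2 gives 425 nM. Among the measured compounds shown here, of the two, compound 1 has the lower number, and the gap between them lies beyond the usual scatter, so compound 1 is the more potent of the two measured so far.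

Compound 3 `CCC(C)(C)Cc1c[nH]c(CCc2ccc(-c3cnccn3)cc2)n1` has not yet been tested. It differs from compound 1 in one place: pyrazin-2-yl in place of 6-aminopyridin-2-yl on an aromatic carbon. The group that leaves carries one hydrogen-bond donor; the group that enters carries none.

For the measured compounds named here, no step between two measured compounds isolates this change, so the expectation rests on compound 1 alone. For compound 3 a moderate step toward a higher number is expected, a 4.1-fold higher number from compound 1 to compound 3 (0.61 log units; beyond the scatter), with the estimate for compound 3 at 150 nM in this assay, within a range from 50 nM to 500 nM.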

Compound 3, half-maximal effective concentration: 431 nM
Compound 3: middle estimate off by 2.9-fold (0.46 log units), on the low side; the measured number falls inside the stated range.
By their numbers in this assay, from the lowest: compound 1; then compounds 2 and 3 (each within the scatter of the next).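

In this assay, among the compounds shown here, putting pyrazin-2-yl in place of 6-aminopyridin-2-yl, on an aromatic carbon para to a large group, gives a 12-fold higher number from compound 1 to compound 3 (1.07 log units; beyond the scatter), the first look at this position with the rest of the structure held constant. This single position can therefore shift the number by a large step, although the leaving group carries one hydrogen-bond donor and the entering group none, and the two rings also differ in their hetero atoms and heavy atoms, so no one of these differences can be singled out. No measurement at hand gives a cause for this step.

Whether the amino group alone accounts for the step remains open, a question for pyridin-2-yl at this position on the rest of compound 1. Also open, as far as these compounds go, is how a methylamino or a hydroxyl group would read in place of that amino group.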